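A few compounds are considered here, and "the series" means these few. Any claim that something is new, unique, unknown or untested is made for them only; others in the source may bear on it.

Measured so far:
compound 1 `N[C@@H](COP(=O)(O)OCCCOC(=O)CCc1ccccc1OCc1cccc(Oc2ccccc2)c1)C(=O)O`: 0.48
compound 2 `Cc1ccccc1Oc1cccc(COc2ccccc2CCC(=O)OCCCOP(=O)(O)OC[C@H](N)C(=O)O)c1`: 0.28

In an assay on cells for activation of probable G-protein coupled receptor 34 (Mus musculus), with a stated time of 1 h (on this read-out higher numbers stand for larger maximal responses and lower numbers for smaller maximal responses), compound 1 stands highest of the two numbers shown, with compound 2 as its only neighbour, a step a number 0.20 lower from compound 1 to compound 2 (beyond the scatter), made by methyl in place of hydrogen on an aromatic carbon. Compound 3 `Cc1ccccc1-c1ccc(Oc2cccc(COc3ccccc3CCC(=O)OCCCOP(=O)(O)OC[C@H](N)C(=O)O)c2)cc1` arises from compound 1 by 2-methylphenyl in place of hydrogen on an aromatic carbon. Among the compounds with values here, the one measured step bearing on it is the drop from compound 1 to compound 2, which was modest yet beyond the scatter; a larger group entering at an aromatic carbon is therefore expected to lower the maximal response again, a number 0.18 lower from compound 1 to compound 3 (beyond the scatter). For compound 3 the estimate is 0.3, ranging from 0.1 to 0.55.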

Compound 3, intrinsic activity: the largest response reached, as a fraction of the reference agonist's: 0.94
Compound 3: middle estimate off by 0.64, on the low side; the whole stated range lies below it.
By their numbers in this assay, from the lowest: compound 2; then compound 1; then compound 3.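

In this assay the step for 2-methylphenyl on an aromatic carbon para to a large group is a number 0.46 higher from compound 1 to compound 3 (beyond the scatter) and so runs opposite to the methyl change, which gave a number 0.20 lower from compound 1 to compound 2 (beyond the scatter). A whole added ring is therefore accepted at this position, and the effect of a small methyl does not predict that of a larger aryl group. No measurement here accounts for the opposite directions. Still open, from the compounds shown here alone, is whether plain phenyl without the methyl gives the same rise, and how an amine or a carboxylic acid at this carbon would compare.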